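This account rests on a few compounds, and the source may have more. Where it says the series, first, only, none or still open, it means among the compounds named here.

In a functional assay for antagonist activity at Neuropeptide Y receptor type 5 (Homo sapiens) (on this read-out higher numbers stand for weaker inhibition and lower numbers for stronger inhibition), compound 1 `Cc1ncccc1N1C[C@]2(CC[C@@H](CNc3cnn(-c4ccccc4F)c3)CC2)OC1=O` gives 0.631 nM. Within the data shown here, compound 2 `O=C1O[C@]2(CC[C@H](CNc3cnn(-c4ccccc4F)c3)CC2)CN1c1cncnc1` gives 0.0398 nM in this assay, the lowest of the two numbers so far, and the single measured step, a 16-fold lower number from compound 1 to compound 2 (1.20 log units; beyond the scatter), shows that swapping the ring on the amide-type nitrogen can shift this read-out a long way. Compound 3 `O=C1O[C@]2(CC[C@H](CNc3cnn(-c4ccccc4F)c3)CC2)CN1c1cccnn1` makes another swap at that same position: pyridazin-3-yl in place of pyrimidin-5-yl on an amide-type nitrogen in a ring. Among the measured compounds shown here, no measured step covers this particular exchange, so its direction is open. Compound 3 is expected to give about 0.1 nM, somewhere from 0.02 nM to 0.6 nM. The expected outcome is thus a 2.5-fold higher number from compound 2 to compound 3 (0.40 log units; beyond the scatter).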

Compound 3, inhibition constant: 0.1 nM
Compound 3: middle estimate and measured number agree at the digits printed; measured number inside the range.
By their numbers in this assay, from the lowest: compound 2; then compound 3; then compound 1.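

Pyridazin-3-yl and pyrimidin-5-yl have the same atoms joined differently, yet the exchange still moves the read-out (a 2.5-fold higher number from compound 2 to compound 3 (0.40 log units; beyond the scatter)), so at this position the arrangement of the ring atoms matters, not just their count. Pyridazin-3-yl also keeps a clear lead over 2-methylpyridin-3-yl (a 6.3-fold lower number from compound 1 to compound 3 (0.80 log units; beyond the scatter)), making this the second ring seen to beat that group. No measurement here explains the difference between the two rings. From the compounds shown here alone, how pyrazin-2-yl or a plain phenyl ring on that nitrogen would compare with compound 2 remains open.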